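A few compounds are considered here, and "the series" means these few. Any claim that something is new, unique, unknown or untested is made for them only; others in the source may bear on it.

Compound 2, `CN(C)CCCOc1ccc(CN2CC[C@H](NC(=O)CNC(=O)c3ccc(Cl)c(Cl)c3)C2)cc1`, is the point of departure for this step. In an assay on HEK293 cells for binding affinity to Urotensin-2 receptor (Homo sapiens), read by radioligand binding (on this read-out lower numbers stand for stronger inhibition and higher numbers for weaker inhibition), compound 2 gives only a limit of the assay, < 10000 nM, so no exact number is known for it. Compound 1, `CC(C)C[C@H](NC(=O)c1ccc(Cl)c(Cl)c1)C(=O)N[C@H]1CCN(Cc2ccc(OCCCN(C)C)cc2)C1`, differs from compound 2 only at one carbon of the chain between the two amide groups, where it carries an isobutyl group instead of a hydrogen; in this assay compound 1 gives 126 nM. The step from compound 1 to compound 2 is a step that the limit leaves unreadable from compound 1 to compound 2, and its size cannot be read because the limit of < 10000 nM in this assay, at which 1 of the 2 values shown sits, is all that stands for compound 2.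

Compound 3, `CN(C)CCCOc1ccc(CN2CC[C@H](NC(=O)[C@H](CCC(=O)O)NC(=O)c3ccc(Cl)c(Cl)c3)C2)cc1`, is made from compound 2 by the change (2-carboxyethyl in place of hydrogen on a saturated chain carbon bound to an amide-type nitrogen and a carbonyl carbon). Going by the values given here, the only measured step touches the same carbon, but its size is hidden by the limit, so no measured step gives a usable size for this one. The step from compound 2 to compound 3 is therefore estimated with wide uncertainty as a step that the limit leaves unreadable from compound 2 to compound 3. Compound 3 is expected to give about 2500 nM in this assay, within a range from 300 nM to 10000 nM.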

Compound 3, inhibition constant: < 10000 nM
Compound 3 was reported as a limit; the forecaster's own chance of this, stated with the estimate: 40%; the middle value is on the limit's open side.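

In this assay compound 3 gives < 10000 nM, which is a limit of the assay and not a number. The steps to compound 3 from compound 1 and from compound 2 cannot be read, because only a limit stands for compound 3: the limit of < 10000 nM in this assay, at which 2 of the 3 values shown sit.

Still open, from the compounds shown here alone, is where compound 2 and compound 3 really lie, and whether 2-carboxyethyl in place of hydrogen changes the read-out at all.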